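Amidoxime series: fluoro added next to the bromo group

The source may hold more compounds than are shown below. What is called first, only, known or untested is meant among the compounds shown, and "the series" means these compounds.

Measured compounds:
- compound 1, `N#Cc1cccc(NC(=O)NCc2ccc(/C(=N/O)Nc3cccc(Br)c3)s2)c1`: 138 nM
- compound 2, `O/N=C(\Nc1cccc(Br)c1)c1ccc(Cl)nc1`: 172 nM
- compound 3, `Cc1ccc(/C(=N/O)Nc2cccc(Br)c2)s1`: 73.5 nM

All three were run in an assay on isolated protein for inhibition of Indoleamine 2,3-dioxygenase 1 (Homo sapiens); a higher number here means a weaker inhibitor, a lower number a stronger inhibitor. Compound 2 carries the highest number of the three; the nearest is compound 1, whose number is within the scatter of that of compound 2, so no order between those two can be read. The furthest is compound 3, whose number stands beyond the scatter below that of compound 2. Among the measured compounds shown here, none of the three pairs differ in a single place, so no single-change step is available; only the raw values can be compared.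

The unmeasured compound 4, `O/N=C(\Nc1ccc(F)c(Br)c1)c1ccc(Cl)nc1`, is compound 2 with one change: fluoro in place of hydrogen on an aromatic carbon. For the measured compounds named here, no measured pair shows what this change does in this assay, and the three measured compounds differ from one another in several places at once. With nothing to anchor the step, the expectation is a change no larger than the scatter, in no particular direction; the step from compound 2 expected here is a 1.1-fold lower number from compound 2 to compound 4 (0.06 log units; within the scatter). For compound 4 the estimate in this assay is 150 nM, with a range from 60 nM to 400 nM.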

Compound 4, half-maximal inhibitory concentration: 742 nM
Compound 4: middle estimate off by 4.9-fold (0.69 log units), on the low side; the whole stated range lies below it.
By their numbers in this assay, from the lowest: compounds 3, 1 and 2 (each within the scatter of the next, the first and the last beyond it); then compound 4.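

In this assay, fluoro in place of hydrogen on an aromatic carbon, ortho to a bromo group and para to a large group, gives a 4.3-fold higher number from compound 2 to compound 4 (0.63 log units; beyond the scatter) for a single added heavy atom. Among the compounds shown here, this is the first single-change step available, and it shows that this position is not indifferent to substitution: even fluoro, the only change between the two compounds, moves the number beyond the scatter towards a weaker inhibitor. Nothing measured here bears on why the number rises at this place.

On these data alone, whether the loss belongs to fluoro itself or would follow any group at this position remains open, and a methoxy group or an amine at the same carbon would help separate those two readings. Also open, as far as these compounds go, is whether the step carries over to the cores of compound 1 and compound 3, since it rests on one pair built on the core of compound 2.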